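The source may report more compounds than this note shows. Statements on the series, on what has been measured and on what is new or still open speak of the compounds shown alone.

Measured in an ADME assay on Huh-7 cells (Homo sapiens) for cytotoxicity, with a stated time of 72 h; on this read-out higher numbers stand for lower toxicity in this test and lower numbers for higher toxicity in this test:
- compound 1 `CC(C)(C)CCn1nc(-c2cccs2)c(O)c(C2=NS(=O)(=O)c3cc(NS(C)(=O)=O)ccc3N2)c1=O`: > 1000 nM
- compound 2 `CC(C)CC(C)n1nc(-c2cccs2)c(O)c(C2=NS(=O)(=O)c3cc(NS(C)(=O)=O)ccc3N2)c1=O`: > 33000 nM

Compound 2 is known only as a limit, > 33000 nM. Compound 1 is likewise known only as a limit, > 1000 nM.

Compound 3 `CCC(C)n1nc(-c2cccs2)c(O)c(C2=NS(=O)(=O)c3cc(NS(C)(=O)=O)ccc3N2)c1=O` differs from compound 2 by methyl in place of isopropyl on a saturated chain carbon, two bonds along the chain from an aromatic nitrogen. Among the compounds with values here, the one measured step touching this chain is a step that the two limits leave unreadable from compound 1 to compound 2, and it gives no size to carry over. No shift beyond the scatter is therefore expected in this assay, in either direction, and the reading rests on compound 2 at its limit of > 33000 nM. The expected step is a number no higher from compound 2 to compound 3 (the limit leaves the size open), and another report as a limit is likely. For compound 3 the estimated value is 33000 nM, with an expected range from 10000 nM to 100000 nM.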

Compound 3, half-maximal cytotoxic concentration: > 33000 nM
Compound 3: only a limit was reported; the forecaster's own chance of this, stated with the estimate: 80%; the middle value lies on the limit itself.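

In this assay compound 3 stands only as a limit, > 33000 nM. Within the data shown here, compound 1 and compound 2 are also limits, so no step among the three can be read. Where each compound's actual half-maximal cytotoxic concentration lies stays open, and with it whether changing the chain on the aromatic nitrogen shifts this read-out at all.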